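Replacing the methoxypyridine in compound 1

A few compounds are considered here, and "the series" means these few. Any claim that something is new, unique, unknown or untested is made for them only; others in the source may bear on it.

Compound 1 `COc1cccc(Nc2cc3[nH]c(-c4cccc(C(F)(F)F)c4)nc3cn2)n1` gives 49% in an ADME assay on microsomes from liver (Rattus norvegicus) for metabolic stability, read by LC-MS, with a stated time of 30 min, tested at 0.1 uM; a lower number here means that less of the compound is left, a higher number that more of the compound is left
Compound 2 `FC(F)(F)c1cccc(-c2nc3cnc(Nc4cccnn4)cc3[nH]2)c1` gives 69% in this assay

Of these two numbers compound 1 holds the lower, and the gap to compound 2 lies beyond the scatter. Compound 3 `Fc1ccc(Nc2cc3[nH]c(-c4cccc(C(F)(F)F)c4)nc3cn2)nc1` has not yet been measured. The change from compound 1 to compound 3 is 5-fluoropyridin-2-yl in place of 6-methoxypyridin-2-yl on a nitrogen on an aromatic ring and reads 5-fluoropyridin-2-yl in place of 6-methoxypyridin-2-yl on a nitrogen on an aromatic ring. Going by the values given here, one measured step bears on it, a number 20 percentage points higher from compound 1 to compound 2 (beyond the scatter) with pyridazin-3-yl replacing the same group. Among the compounds with values here, that is the only such replacement measured, and its entering group is not the one in compound 3. Resting on a number 20 percentage points higher from compound 1 to compound 2 (beyond the scatter) as the sole guide, a smaller rise is expected in this assay for this change. The estimated step is a number 11 percentage points higher from compound 1 to compound 3 (beyond the scatter) and remains uncertain. Compound 3 is expected at 60% within an estimated range from 42% to 76% when measured.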

Compound 3, percent of the compound remaining: 42%
Compound 3: the middle estimate sits 18 percentage points above what was measured; the range from low to high includes it.
By their numbers in this assay, from the lowest: compounds 3 and 1 (each within the scatter of the next); then compound 2.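

Putting 5-fluoropyridin-2-yl in place of 6-methoxypyridin-2-yl on the nitrogen gives a number 7 percentage points lower from compound 1 to compound 3 (within the scatter) in this assay, so this exchange of one substituted pyridine for another does not separate the two compounds. Putting 5-fluoropyridin-2-yl in place of pyridazin-3-yl gives a number 27 percentage points lower from compound 2 to compound 3 (beyond the scatter), which is a step of the same kind of size as the one first seen with pyridazin-3-yl. Among these three groups at this place, only pyridazin-3-yl stands apart, while the two pyridin-2-yl groups read alike despite carrying methoxy and fluorine at different places.

Nothing available gives a reason for this difference. Going by these compounds, it remains open whether an unsubstituted pyridin-2-yl, a pyrimidin-2-yl or a pyridazine ring carrying a methoxy group would read like compound 2 or like compound 3.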